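This account rests on a few compounds, and the source may have more. Where it says the series, first, only, none or still open, it means among the compounds named here.

In a functional assay on MCF7 cells (Homo sapiens) for antiproliferative activity, read by MTT assay, with a stated time of 48 h (a lower number here means a stronger inhibitor, a higher number a weaker inhibitor), compound 1 `C=CCN(C)C(=O)c1ccc(C(CC)(CC)c2ccc(OCCC(O)(CC)CC)c(C)c2)n1CC` gives > 50000 nM, which is a limit of the assay and not a number. Compound 2 `CCC(C)C(NC(=O)c1ccc(C(CC)(CC)c2ccc(OCCC(O)(CC)CC)c(C)c2)n1CC)C(=O)OC` gives > 50000 nM, and this too is a limit rather than a number. The picture so far is therefore (the limit of > 50000 nM in this assay, at which 2 of the 2 values shown sit). For the measured compounds named here, the one measured step, a step that the two limits leave unreadable from compound 1 to compound 2, has no readable size and offers no direction to carry forward.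

Compound 3 `CCOC(=O)C(CC(=O)OC)NC(=O)c1ccc(C(CC)(CC)c2ccc(OCCC(O)(CC)CC)c(C)c2)n1CC` departs from compound 2 through (a group of 11 heavy atoms (7 carbon, 4 oxygen; no ring) in place of a group of 9 heavy atoms (7 carbon, 2 oxygen; no ring), on an amide-type nitrogen). Going by the values given here, with no sized step to draw on, no definite shift in this assay can be expected, and the reading seems likely to stay close to the limit reached by compound 2 at > 50000 nM. The expected change is a number no higher from compound 2 to compound 3 (the limit leaves the size open). Compound 3 is estimated at 50000 nM, with an expected range from 15000 nM to 100000 nM.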

Compound 3, half-maximal inhibitory concentration: 390 nM
The estimate for compound 3 lay 130-fold (2.11 log units) above the measured number; the measured number lies below the stated range.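

On the amide-type nitrogen, the group of 11 heavy atoms in place of the group of 9 heavy atoms gives an at least 120-fold lower number from compound 2 to compound 3 (2.10 log units; beyond the scatter), so the group at this place can decide whether this assay returns a readable number at all. At the carbonyl carbon, the change from the group of compound 1 to the group of compound 3 gives an at least 120-fold lower number from compound 1 to compound 3 (2.10 log units; beyond the scatter). Compound 3 is the only compound shown with a number rather than a limit: the limit of > 50000 nM in this assay, at which 2 of the 3 values shown sit.

The compounds shown leave open which part of the entering group accounts for the step, and whether it would survive with a carboxylic acid in place of either ester or with a longer chain on the same nitrogen. On these data alone, the full size of both steps also stays open, as each starts from a limit.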